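This account rests on a few compounds, and the source may have more. Where it says the series, first, only, none or still open, it means among the compounds named here.

- Compound 1 `COc1ccccc1/C=C1\CCC/C(=C\c2ccc(OC)c(OC)c2)C1=O`: > 20000 nM (a limit)
- Compound 2 `COc1cccc(/C=C2\CCC/C(=C\c3ccc(OC)c(OC)c3)C2=O)c1`: 6700 nM
- Compound 3 `COc1ccc(/C=C2\CCC/C(=C\c3ccc(O)cc3)C2=O)cc1OC`: > 20000 nM (a limit)

All three were tested in a functional assay on A549 cells (Homo sapiens) for cytotoxicity, read by MTT assay, with a stated time of 72 h; a higher number here means a weaker inhibitor, a lower number a stronger inhibitor. Compound 3 has only a limit and no number: > 20000 nM. This is the limit of > 20000 nM in this assay, at which 2 of the 3 values shown sit.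

Compound 4 `COc1ccc(/C=C2\CCC/C(=C\c3cccc(Cl)c3Cl)C2=O)cc1OC` has 2,3-dichlorophenyl in place of 4-hydroxyphenyl, on a double-bonded chain carbon bound to a double-bonded ring carbon: 2,3-dichlorophenyl in place of 4-hydroxyphenyl on a double-bonded chain carbon bound to a double-bonded ring carbon.

Two measured steps change the group at this same place, an at least 2.9-fold lower number from compound 1 to compound 2 (0.47 log units; beyond the scatter) and an at least 2.9-fold higher number from compound 2 to compound 3 (0.47 log units; beyond the scatter), both beyond the scatter. By contrast, a step that the two limits leave unreadable from compound 1 to compound 3 cannot be sized. These steps run in both directions, so only a modest fall is expected, and compound 4 may also stay at the limit. The estimated step is an at least 2.0-fold lower number from compound 3 to compound 4 (0.30 log units; that floor lies within the scatter). For compound 4 the expected value is 10000 nM, with an estimated range from 3000 nM to 30000 nM.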

Compound 4, half-maximal inhibitory concentration: > 20000 nM
Compound 4 gave a limit, no number; the forecaster's own chance of this, stated with the estimate: 40%; middle value at least 2.0-fold (0.30 log units) away from the limit.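

In this assay, compound 4 also ends at a limit of the assay (> 20000 nM), so a chlorinated ring with no hydrogen-bond donor at this place gives no measurable value either. With 3-methoxyphenyl replaced by 2,3-dichlorophenyl, the result is an at least 2.9-fold higher number from compound 2 to compound 4 (0.47 log units; beyond the scatter), which leaves compound 2 as the only compound shown with a number. The steps from compound 1 and compound 3 to compound 4 cannot be read, and the limit now covers most of the series: the limit of > 20000 nM in this assay, at which 3 of the 4 values shown sit.

From the compounds shown here alone, it remains open whether a phenyl ring carrying an amine, a carboxylic acid or a single chlorine would give a number here.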